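A few compounds are considered here, and "the series" means these few. Any claim that something is new, unique, unknown or untested is made for them only; others in the source may bear on it.

Compound 1 `CCCc1nn(C)c2c(NC3CC3)nc(/C=C/c3nc(C)c(C)nc3C)nc12`: 706000 nM
Compound 2 `FC(F)(F)c1ccc(Nc2nc(/C=C/c3ccccc3)nc3ccsc23)cc1`: > 1000000 nM
Compound 3 `COc1cc(/C=C/c2nc(N(C)C)c3sccc3n2)cc(OC)c1OC`: > 1000000 nM

All three compounds were tested in a functional assay on L02 cells (Homo sapiens) for inhibition, read by Griess assay, with stated times of 1 h and 24 h; a lower number here means a stronger inhibitor, a higher number a weaker inhibitor. Compound 3 gives > 1000000 nM, which is a limit of the assay and not a number. Compound 2 gives > 1000000 nM, which is also a limit. Among the measured compounds shown here, compound 1 gives 706000 nM, the only true number so far. The set as a whole shows (the limit of > 1000000 nM in this assay, at which 2 of the 3 values shown sit).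

Compound 4 `COc1cc(/C=C/c2nc(N3CCCC3)c3sccc3n2)cc(OC)c1OC` is compound 3 with one change: pyrrolidin-1-yl in place of dimethylamino on an aromatic carbon, next to the ring nitrogen (pyrrolidin-1-yl in place of dimethylamino on an aromatic carbon). For the measured compounds named here, no two measured compounds differ in just one place, so no measured step gives the size of this swap. The expectation in this assay is therefore no change beyond the usual scatter, in neither direction. That expectation starts from compound 3, whose limit is > 1000000 nM. The estimated step of a number no higher from compound 3 to compound 4 (the limit leaves the size open) is accordingly small. For compound 4 the estimated value is 1000000 nM, with an expected range of 400000 nM to 2000000 nM. The assay may well report only a limit again.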

Compound 4, half-maximal inhibitory concentration: 681000 nM
The estimate for compound 4 lay 1.5-fold (0.17 log units) above the measured number; measured number inside the range.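

Among the compounds shown here, replacing dimethylamino with pyrrolidin-1-yl on an aromatic carbon, next to the ring nitrogen, gives the one step available in this assay: an at least 1.4-fold lower number from compound 3 to compound 4 (0.16 log units; that floor lies within the scatter). On these data alone, compound 3 gives > 1000000 nM, which is a limit of the assay and not a number, so the real size of this step stays unknown and it cannot be said to pass the scatter. Compound 4 gives 681000 nM, a true number, which offers the first fixed reference point for this position on this core, and it shows that a five-membered non-aromatic ring can sit here with a measured reading.

The compounds shown leave open whether a piperidin-1-yl or morpholin-4-yl group at this position, or the same swap on the core of compound 1, would give a clearly lower number. Any such comparison would start from a thin base, with many readings still at the top of what the assay can report: the limit of > 1000000 nM in this assay, at which 2 of the 4 values shown sit.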